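The source may report more compounds than this note shows. Statements on the series, on what has been measured and on what is new or still open speak of the compounds shown alone.

Compound 1 `CC1=C(C)C(=O)C(c2cn([C@H]3C[C@H](O)[C@@H](CO)O3)c(=O)[nH]c2=O)=C(C)C1=O`: 174000 nM
Compound 2 `Nc1ncnc2c1ncn2C1C[C@@H](CO)[C@@H](CO)C1`: > 200000 nM
Compound 3 `COCC#Cc1cn([C@H]2C[C@H](O)[C@@H](CO)O2)c(=O)[nH]c1=O`: > 200000 nM

Of the compounds shown here, three have been tested in an ADME assay on L1210/0 cells (Mus musculus) for cytotoxicity, with a stated time of 48 h; on this read-out lower numbers stand for stronger inhibition and higher numbers for weaker inhibition. Compound 1 gives a number, 174000 nM. Compound 2 returns only a limit of the assay, > 200000 nM. Compound 3 likewise returns only a limit, > 200000 nM. Compound 3 therefore stands at the weak edge of what the assay can report, a position it shares with compound 2, (the limit of > 200000 nM in this assay, at which 2 of the 3 values shown sit). Compound 4 `O=c1[nH]c(=O)n([C@H]2C[C@H](O)[C@@H](CO)O2)cc1O` differs from compound 3 in one place: hydroxy in place of 3-methoxyprop-1-yn-1-yl on an aromatic carbon. Going by the values given here, no step between measured compounds is available to calibrate this change. Since compound 3 offers only its limit > 200000 nM as a starting point, the step is expected to be none beyond the scatter, a step that the limit leaves unreadable from compound 3 to compound 4. Compound 4 is estimated at 250000 nM, between 100000 nM and 600000 nM, most likely reported again only as a limit.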

Compound 4, half-maximal inhibitory concentration: > 200000 nM
Compound 4: no number, only a limit; the forecaster's own chance of this, stated with the estimate: 85%; the middle value lies beyond the limit too.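

Compound 3 and compound 4 both return only a limit, so no step can be read between them. The compounds shown leave open whether swapping 3-methoxyprop-1-yn-1-yl for hydroxy changes cytotoxicity at all.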